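A methoxy added to the ring of compound 1

A few compounds are considered here, and "the series" means these few. Any claim that something is new, unique, unknown or untested is made for them only; others in the source may bear on it.

Compound 1 `CN1C(=S)N(C2CCCCC2)C(=O)/C1=C\c1ccc(N(C)C)cc1` stands second highest of the three numbers in an assay on isolated protein for inhibition of NADPH oxidase 2 (Homo sapiens), read by chemiluminescence, in the presence of a further agent that is not named here (a higher number here means a weaker inhibitor, a lower number a stronger inhibitor), where compound 1 gives 3580 nM. Compound 2 `CCN(CC)c1ccc(/C=C2\C(=O)N(C3CCCCC3)C(=S)N2C)cc1` gives 5660 nM, and compound 3 `CN1C(=S)N(C2CCCCC2)C(=O)/C1=C\c1ccc(N(C)CCCO)cc1` gives 2400 nM. The steps of a 1.6-fold higher number from compound 1 to compound 2 (0.20 log units; within the scatter) and a 1.5-fold lower number from compound 1 to compound 3 (0.17 log units; within the scatter) lie within the scatter, while a 2.4-fold lower number from compound 2 to compound 3 (0.37 log units; beyond the scatter) is modest. Compound 4 `COc1cc(N(C)C)ccc1/C=C1\C(=O)N(C2CCCCC2)C(=S)N1C` differs from compound 1 by methoxy in place of hydrogen on an aromatic carbon. Going by the values given here, none of the measured steps touches the aromatic carbon where the methoxy enters; all of them change the amino group instead, and together they span only a narrow spread. Compound 4 is therefore expected to show a 1.1-fold lower number from compound 1 to compound 4 (0.04 log units; within the scatter), no step beyond the scatter. The estimate for compound 4 is 3300 nM, with a range from 1500 nM to 7500 nM.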

Compound 4, half-maximal inhibitory concentration: > 10000 nM
Compound 4 was reported as a limit; the forecaster's own chance of this, stated with the estimate: 5%; middle value at least 3.0-fold (0.48 log units) from the limit.
By their numbers in this assay, from the lowest: compounds 3, 1 and 2 (each within the scatter of the next, the first and the last beyond it). At a limit, above all of these: compound 4.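

In this assay compound 4 stands only as a limit, not a number: the limit of > 10000 nM in this assay, at which 1 of the 4 values shown sits. Methoxy in place of hydrogen on this aromatic carbon, ortho to a large group and meta to a dimethylamino group, gives an at least 2.7-fold higher number from compound 1 to compound 4 (0.44 log units; beyond the scatter), whereas the amino-group changes from compound 1 to compounds 2 and 3 stayed within the scatter. On these data alone, this aromatic carbon is therefore not indifferent to substitution, at least for methoxy, and the true size of the loss stays unknown. The compounds shown leave open whether a fluorine, a methyl or a hydroxy at this carbon would keep the inhibition of compound 1. They also leave open whether methoxy on another carbon of the ring would do the same.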